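Swapping a Basic Amine Arm for Methylsulfonyl

The compounds below may be only part of what the source reports. "The series", "measured", "known", "first", "only" and "open" are said of these compounds alone.

Measured compounds:
- Compound 1, `Cc1cc(C)cc(S(=O)(=O)c2c(C(=O)N[C@@H]3CCN(Cc4cccnc4)C3)[nH]c3ccc(Cl)cc23)c1`: 36500 nM
- Compound 2, `Cc1cc(C)cc(S(=O)(=O)c2c(C(=O)N[C@H]3CCN(Cc4n[nH]c(=O)n4C)C3)[nH]c3ccc(Cl)cc23)c1`: 21500 nM
- Compound 3, `Cc1cc(C)cc(S(=O)(=O)c2c(C(=O)NC3CN(Cc4ccccc4C#N)C3)[nH]c3ccc(Cl)cc23)c1`: > 234000 nM (a limit of the assay, not a number)

In an ADME assay on MT4 cells (Homo sapiens) for cytotoxicity, read by MTT assay, with a stated time of 5 days (on this read-out higher numbers stand for lower toxicity in this test and lower numbers for higher toxicity in this test), compound 1 gives 36500 nM. Compound 2 gives 21500 nM in this assay, and the two values lie within the scatter of each other, so neither can be called more or less toxic than the other. For compound 3 this assay returned only > 234000 nM, which is a limit rather than a number; (the limit of > 234000 nM in this assay, at which 1 of the 3 values shown sits).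

Compound 4, `Cc1cc(C)cc(S(=O)(=O)c2c(C(=O)NS(C)(=O)=O)[nH]c3ccc(Cl)cc23)c1`, is not yet measured. It differs from compound 1 in one place: methylsulfonyl in place of 1-((pyridin-3-yl)methyl)pyrrolidin-3-yl on an amide-type nitrogen. The shared core, with its chloro-substituted indole and dimethylphenylsulfonyl group, is kept unchanged.

Going by the values given here, no measured pair of compounds shows a change of this kind, so the expected step rests on the structures alone. The group that leaves is large and carries a pyridine and a pyrrolidine ring; the group that enters is small. Compound 4 is expected to be less toxic than compound 1 in this assay, with a step of a 2.5-fold higher number from compound 1 to compound 4 (0.39 log units; beyond the scatter) beyond the scatter, though with a fair chance that only a limit is reported. The estimate for compound 4 is 90000 nM, within a range of 30000 nM to 250000 nM.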

Compound 4, half-maximal cytotoxic concentration: 40200 nM
Compound 4: the middle estimate sits 2.2-fold (0.35 log units) above what was measured; the measured number falls inside the stated range.
By their numbers in this assay, from the lowest: compounds 2, 1 and 4 (each within the scatter of the next). At a limit, above all of these: compound 3.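

Setting methylsulfonyl in place of 1-((pyridin-3-yl)methyl)pyrrolidin-3-yl on an amide-type nitrogen gives, in this assay, a 1.1-fold higher number from compound 1 to compound 4 (0.04 log units; within the scatter). Going by these compounds alone, this is the first comparison here of compounds that differ in one place, and it shows that the pyridine ring, the pyrrolidine ring and the defined stereocentre can all leave this position without a change that stands clear of the scatter. Compound 3 remains the only compound reported as a limit, which is not a number: the limit of > 234000 nM in this assay, at which 1 of the 4 values shown sits.

A single step cannot show whether other small groups on the same nitrogen, such as acetyl or a short chain ending in a carboxylic acid, would give a similar reading. Nor does it tell why the reading holds steady across so large a swap.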